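Methoxycarbonyl in Place of Methyl on the Aromatic Ring

The source may hold more compounds than are shown below. What is called first, only, known or untested is meant among the compounds shown, and "the series" means these compounds.

Measured so far:
compound 1, `Cc1ccc(N2C(=O)C=CC2OCC(F)(F)F)cc1`: 15800 nM
compound 2, `O=C1C=CC(OCC(F)(F)F)N1c1cc(F)cc(F)c1`: 7840 nM
compound 3, `O=C1C=CC(OCC(F)(F)F)N1c1ccc(Cl)cc1F`: 6100 nM

In a functional assay on MDA-MB-231 cells (Homo sapiens) for inhibition (on this read-out higher numbers stand for weaker inhibition and lower numbers for stronger inhibition), compound 1 shows the highest number of the three. Compound 2 lies within the usual scatter of compound 1, so the two cannot be told apart, whereas compound 3 sits beyond the scatter with a lower number, meaning stronger inhibition.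

Compound 4, `COC(=O)c1ccc(N2C(=O)C=CC2OCC(F)(F)F)cc1`, keeps the shared core of compound 1 and differs in one place: methoxycarbonyl in place of methyl on an aromatic carbon. Going by the values given here, no measured pair shows what such a swap does, so the expectation rests only on the spread seen so far. In this assay the expected step of a 1.3-fold lower number from compound 1 to compound 4 (0.12 log units; within the scatter) is small and may fall either way. Compound 4 is therefore estimated at 12000 nM, with a range from 4000 nM to 40000 nM.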

Compound 4, half-maximal inhibitory concentration: 12100 nM
Compound 4: the middle estimate sits 1.0-fold (0.00 log units) below what was measured, within the range that was stated.
By their numbers in this assay, from the lowest: compounds 3, 2, 4 and 1 (each within the scatter of the next, the first and the last beyond it).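

In this assay methoxycarbonyl in place of methyl on this aromatic carbon, para to a large group, gives a 1.3-fold lower number from compound 1 to compound 4 (0.12 log units; within the scatter) and so leaves the two compounds indistinguishable. This position therefore accepts a larger group carrying hydrogen-bond acceptors, where methyl has none, without a measurable gain or loss in inhibition. Nothing measured here accounts for this result.

Going by these compounds, whether a carboxylic acid or an amine on this same carbon would also match methyl remains open. So does whether a longer ester, such as ethoxycarbonyl, would do the same.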